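This account rests on a few compounds, and the source may have more. Where it says the series, first, only, none or still open, it means among the compounds named here.

Working notes on the series. Going by the values given here, in a functional assay on MCF7 cells (Homo sapiens) for antiproliferative activity, read by MTT assay (on this read-out lower numbers stand for stronger inhibition and higher numbers for weaker inhibition), compound 1 `CC(=O)c1ccc(-n2cc(COc3ccc(/C=C/C(=O)c4ccc5c(c4O)CCC(C)(C)O5)cc3)nn2)cc1` gives 171000 nM while compound 2 `CC1(C)CCc2c(ccc(C(=O)/C=C/c3ccc(OCc4cn(Cc5ccc([N+](=O)[O-])cc5)nn4)cc3)c2O)O1` gives 17100 nM as the lower of the two numbers so far. Compound 3 `CCCCCCCCn1cc(COc2ccc(/C=C/C(=O)c3ccc4c(c3O)CCC(C)(C)O4)cc2)nn1` has not yet been measured in this assay and differs from compound 2 by heptyl in place of 4-nitrophenyl on a saturated chain carbon bound to an aromatic nitrogen in the form of heptyl in place of 4-nitrophenyl on a saturated chain carbon bound to an aromatic nitrogen, which reads as 4-nitrobenzyl to octyl when cut one bond further out.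

Among the compounds with values here, the only measured step that bears on this change is a 10-fold lower number from compound 1 to compound 2 (1.00 log units; beyond the scatter) with 4-nitrobenzyl in place of 4-acetylphenyl on an aromatic nitrogen, and it lies beyond the scatter. Within the data shown here, that step shows that the group on this nitrogen can move the number, but both groups carry an aromatic ring and no compound with an open chain there has been measured. Neither its size nor its direction carries over, so the central expectation in this assay is no step beyond the scatter, although a step of similar size in either direction remains possible. The expected step is a 1.2-fold higher number from compound 2 to compound 3 (0.07 log units; within the scatter) as a central estimate. For compound 3 the estimate is 20000 nM with an expected range from 6000 nM to 70000 nM for the measurement.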

Compound 3, half-maximal inhibitory concentration: "not active" (no number reported)
Compound 3 has no reported number here; there is nothing to compare the estimate with.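

In this assay, going by these compounds alone, compound 3 is recorded as "not active" without a number, so no step from compound 2 to compound 3 can be read. Nothing available explains this result. The compounds shown leave open how far octyl in place of 4-nitrobenzyl moves the number, and in which direction.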